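Bromo for hydrogen on the fused ring of compound 2

This account rests on a few compounds, and the source may have more. Where it says the series, first, only, none or still open, it means among the compounds named here.

Measured compounds:
compound 1 `Cc1cccc2c(-c3ccc4ccc(F)cc4n3)c[nH]c12`, 0.883 h
compound 2 `Cc1cccc2c(-c3ccc4ccccc4n3)c[nH]c12`, 0.35 h

In an ADME assay on microsomes from liver (Homo sapiens) for metabolic stability, using NADPH, with a stated time of 40 min, tested at 2 uM (a lower number here means that the compound disappears faster, a higher number that the compound lasts longer), compound 2 gives 0.35 h, the lowest of the two numbers; its nearest neighbour is compound 1, which gives 0.883 h. Compound 3 `Cc1cccc2c(-c3ccc4cccc(Br)c4n3)c[nH]c12` differs from compound 2 by bromo in place of hydrogen on an aromatic carbon. For the measured compounds named here, the one measured step that bears on this is a 2.5-fold lower number from compound 1 to compound 2 (0.40 log units; beyond the scatter), which removed a halogen and lowered the number. A halogen now enters, so a modest rise is expected, a 1.7-fold higher number from compound 2 to compound 3 (0.23 log units; within the scatter). Compound 3 is therefore estimated at 0.6 h, within 0.25 h to 1.5 h.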

Compound 3, half-life: 2.4 h
Compound 3: the middle estimate sits 4.0-fold (0.60 log units) below what was measured; measured number above the stated range.
By their numbers in this assay, from the lowest: compound 2; then compound 1; then compound 3.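

In this assay, bromo in place of hydrogen on an aromatic carbon, ortho to a fused ring, gives a 6.9-fold higher number from compound 2 to compound 3 (0.84 log units; beyond the scatter). This shows that this carbon also accepts a halogen with a rise beyond the scatter, which compound 1 had shown only for fluoro at another carbon. Nothing measured here accounts for the rise. As far as these compounds go, whether chloro, methoxy or an amine on the same carbon would also lengthen the half-life remains open. So does whether bromo and fluoro together on one compound would lengthen it further.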